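The compounds below may be only part of what the source reports. "The series", "measured", "known", "first", "only" and "open" are said of these compounds alone.

Measured so far:
- compound 1, `CC(C)(C)c1ccc(CNCCCNS(=O)(=O)c2cc(C(F)(F)F)cc(C(F)(F)F)c2)cc1`, 2900 nM
- compound 2, `O=S(=O)(NCCNCc1ccc(-c2ccccc2)cc1)c1cc(C(F)(F)F)cc(C(F)(F)F)c1`, 2600 nM

In a functional assay on A2780 cells (Homo sapiens) for inhibition, read by MTT assay, with a stated time of 72 h (on this read-out lower numbers stand for stronger inhibition of growth and higher numbers for weaker inhibition of growth), compound 1 gives the higher of the two numbers; compound 2 sits within the scatter of it, so the two are not distinguished on this read-out. Compound 3, `O=S(=O)(NCCCNCc1ccc(Cl)c(Cl)c1)c1cc(C(F)(F)F)cc(C(F)(F)F)c1`, is not yet measured in this assay. It differs from compound 1 by 3,4-dichlorophenyl in place of 4-(tert-butyl)phenyl on a saturated chain carbon bound to an amine nitrogen. Among the compounds with values here, no measured pair shows such a change, so no direction is known. The step of a 1.0-fold higher number from compound 1 to compound 3 (0.01 log units; within the scatter) is expected to stay within the scatter. Compound 3 is therefore estimated at 3000 nM, with a range from 1200 nM to 7500 nM.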

Compound 3, concentration for 50% growth inhibition: 1500 nM
The estimate for compound 3 lay 2.0-fold (0.30 log units) above the measured number; the range from low to high includes it.
By their numbers in this assay, from the lowest: compounds 3, 2 and 1 (each within the scatter of the next).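

Within the data shown here, at the saturated chain carbon bound to an amine nitrogen, the first single-place comparison gives a 1.9-fold lower number from compound 1 to compound 3 (0.29 log units; within the scatter) in this assay, for 3,4-dichlorophenyl in place of 4-(tert-butyl)phenyl. The two groups are thus not distinguished on this read-out, even though their atoms differ, chlorine entering and the tert-butyl carbons leaving. Nothing available bears on this result. 

From the compounds shown here alone, whether a pyridine ring or a benzoic acid in place of 3,4-dichlorophenyl would separate from compound 1 stays open. Among these compounds, the effect of a longer chain also stays open: compound 2 differs from compound 1 in more than one place, so that pair gives no step.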